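Hydroxyphenyl positions on a trifluoromethylphenyl pyridine core

This account rests on a few compounds, and the source may have more. Where it says the series, first, only, none or still open, it means among the compounds named here.

Compound 1 `Oc1ccccc1-c1cc(-c2cccc(C(F)(F)F)c2)cc(-c2ccccc2O)n1`; compound 2 `Oc1cccc(-c2cc(-c3cccc(C(F)(F)F)c3)cc(-c3ccccc3O)n2)c1`; compound 3 `Oc1ccc(-c2cc(-c3cccc(C(F)(F)F)c3)cc(-c3ccccc3O)n2)cc1`.

In a functional assay on DU-145 cells (Homo sapiens) for inhibition (a lower number here means a stronger inhibitor, a higher number a weaker inhibitor), compound 2 gives 13000 nM. For compound 1 the result is a limit of this assay, > 50000 nM. For compound 3 the result is likewise a limit, > 50000 nM. Compound 3 therefore stands at the upper edge of what this assay can report, together with compound 1, as the limit of > 50000 nM in this assay, at which 2 of the 3 values shown sit, shows, and no numbered value is known for it.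

Compound 4 `Oc1ccc(-c2cc(-c3cccc(C(F)(F)F)c3)cc(-c3cccc(O)c3)n2)cc1` differs from compound 3 in one place: 3-hydroxyphenyl in place of 2-hydroxyphenyl on an aromatic carbon. Among the measured compounds shown here, the one measured step that bears on this change is an at least 3.8-fold lower number from compound 1 to compound 2 (0.58 log units; beyond the scatter), which is the same exchange made on the shared core. The step of an at least 3.8-fold higher number from compound 2 to compound 3 (0.58 log units; beyond the scatter) goes the other way and is also at least modest. On this basis compound 4 is expected to give a lower number than compound 3, by an estimated at least 3.3-fold lower number from compound 3 to compound 4 (0.52 log units; beyond the scatter). Compound 4 is estimated at 15000 nM, within a range from 5000 nM to 50000 nM.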

Compound 4, half-maximal inhibitory concentration: 11100 nM
For compound 4 the middle estimate is 1.4-fold (0.13 log units) above the measured one; the range from low to high includes it.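

In this assay, the exchange of 2-hydroxyphenyl for 3-hydroxyphenyl on the aromatic carbon next to the ring nitrogen now gives an at least 4.5-fold lower number from compound 3 to compound 4 (0.65 log units; beyond the scatter), so the drop seen on one core recurs on a second: the same change on two cores in this assay, an at least 3.8-fold lower number (0.58 log units; beyond the scatter) from compound 1 to compound 2 and an at least 4.5-fold lower number (0.65 log units; beyond the scatter) from compound 3 to compound 4; the limit leaves it open whether they differ With a 3-hydroxyphenyl group already on the core, exchanging 2-hydroxyphenyl for 4-hydroxyphenyl gives a 1.2-fold lower number from compound 2 to compound 4 (0.07 log units; within the scatter), which sets no order between these two groups. Compound 2 and compound 4, which carry a 3-hydroxyphenyl group, give numbered values, whereas compound 1 and compound 3, which carry none, sit at a limit of the assay: the limit of > 50000 nM in this assay, at which 2 of the 4 values shown sit.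

On these data alone, the true size of the exchange on either core stays open, since each step starts from a limit. Also open, as far as these compounds go, is whether an amine in place of the hydroxy group of 3-hydroxyphenyl would hold the numbers seen in this assay.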